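Lipophilicity notes: oxazolidinone side-chain variations, compound 3 to compound 4

The source may report more compounds than this note shows. Statements on the series, on what has been measured and on what is new or still open speak of the compounds shown alone.

Measured compounds:
compound 1 `CN(CCC#N)C[C@H]1CN(c2ccc(-n3cc(-c4ccccn4)cn3)c(F)c2)C(=O)O1` — 1.9
compound 2 `O=C1CNC(=O)N1C[C@H]1CN(c2ccc(-n3cc(-c4ccccn4)cn3)c(F)c2)C(=O)O1` — 1.25
compound 3 `O=C(OC[C@H]1CN(c2ccc(-n3cc(-c4ccccn4)cn3)c(F)c2)C(=O)O1)c1ccccc1` — 4.21

Compound 3 gives the highest number of the three in a physicochemical assay for lipophilicity, read by HPLC, measured as octanol-water partition; a lower number here means a more polar compound, a higher number a more lipophilic compound. Its nearest neighbour is compound 1, and the gap is the step of a number 2.31 log units higher from compound 1 to compound 3 (beyond the scatter); compound 2 lies furthest away, with a number 2.96 log units higher from compound 2 to compound 3 (beyond the scatter). Between the two smaller-chain compounds the step runs a number 0.65 log units lower from compound 1 to compound 2 (beyond the scatter).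

Compound 4 `O=CNC[C@H]1CN(c2ccc(-n3cc(-c4ccccn4)cn3)c(F)c2)C(=O)O1` has not yet been measured in this assay. The change from compound 3 is formylamino in place of benzoyloxy on a saturated chain carbon bound to a saturated ring carbon. Both steps into compound 3, from compound 1 and from compound 2, show that taking the benzoyloxy group off this chain carbon in favour of a smaller group without a ring moves the partition coefficient down by a large amount. The formylamino group is smaller still than either of those two replacements, so a large downward step is expected in this assay, and the number is estimated to land near the range spanned by compounds 1 and 2.

Compound 4 is therefore expected to give 1.5, within 0.9 to 2.1, which means an estimated step of a number 2.71 log units lower from compound 3 to compound 4 (beyond the scatter).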

Compound 4, partition coefficient: 1.19
For compound 4 the middle estimate is 0.31 log units above the measured one; measured number inside the range.
By their numbers in this assay, from the lowest: compounds 4 and 2 (each within the scatter of the next); then compound 1; then compound 3.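

In this assay, replacing benzoyloxy with formylamino on this saturated chain carbon gives a number 3.02 log units lower from compound 3 to compound 4 (beyond the scatter), so the large downward step seen with the two earlier replacements also holds for a group of 3 heavy atoms. Formylamino has no ring and 2,5-dioxoimidazolidin-1-yl has one, yet the step of a number 0.06 log units lower from compound 2 to compound 4 (within the scatter) leaves the two groups unseparated. The step of a number 0.71 log units lower from compound 1 to compound 4 (beyond the scatter) separates formylamino from (2-cyanoethyl)(methyl)amino, which also has no ring, so among these compounds the presence of a ring alone does not order the groups that replace benzoyloxy.

As far as these compounds go, whether a simple amine, a carboxylic acid or a longer acyl chain on this carbon would stay close to compound 2 and compound 4 remains open. No measured evidence available here accounts for these steps.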